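This account rests on a few compounds, and the source may have more. Where it says the series, first, only, none or still open, it means among the compounds named here.

Compound 1 `Cc1cccc(CCCCCCC(=O)N2CCCC2)c1`: 8300 nM
Compound 2 `O=C(CCc1ccc(-c2ccc(F)cc2)cc1)N1CCCC1`: 3400 nM

Among the compounds with values here, in an assay on HEK293 cells for inhibition of N-acylethanolamine-hydrolyzing acid amidase (Rattus norvegicus), read by LC-MS, with a stated time of 30 min (a lower number here means a stronger inhibitor, a higher number a weaker inhibitor), compound 2 gives 3400 nM, the lower of the two numbers measured so far. Compound 1 gives 8300 nM in this assay, and the gap between the two values lies beyond the usual scatter, so compound 2 stands as the stronger inhibitor of this pair.

Compound 3 `O=C(CCc1ccc(-c2ccsc2)cc1)N1CCCC1` differs from compound 2 in one place: thiophen-3-yl in place of 4-fluorophenyl on an aromatic carbon. No measured pair among these compounds shows a change of this kind, so the expectation rests on compound 2 alone and carries a wide range. The step is expected to be small, at most a modest move towards a weaker inhibitor, and it is estimated as a 1.3-fold higher number from compound 2 to compound 3 (0.12 log units; within the scatter). Compound 3 is therefore expected to give about 4500 nM in this assay, with a range from 1500 nM to 14000 nM.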

Compound 3, half-maximal inhibitory concentration: 2500 nM
For compound 3 the middle estimate is 1.8-fold (0.26 log units) above the measured one; low and high end bracket the measured number.
By their numbers in this assay, from the lowest: compounds 3 and 2 (each within the scatter of the next); then compound 1.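

In this assay, thiophen-3-yl in place of 4-fluorophenyl gives a 1.4-fold lower number from compound 2 to compound 3 (0.13 log units; within the scatter). This shows that, at this position para to a group of 9 heavy atoms, a five-membered aromatic ring with one hetero atom can stand in for a six-membered aromatic ring of carbon only with no change beyond the scatter. The fluorine is also absent from compound 3, so this pair gives no sign that the assay needs it at this position. Nothing available explains why the two groups read alike.

The compounds shown leave open whether a pyridine ring, an unsubstituted phenyl ring or a carboxylic acid at this position would also read alike. They also leave open whether the same exchange would hold on a longer chain.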